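Inverting One Ring Carbon Without Changing Any Atom

The source may hold more compounds than are shown below. What is called first, only, known or untested is meant among the compounds shown, and "the series" means these compounds.

Compound 3 `CN(C)[C@@H]1CCN(c2cccc3c2C[C@H](CN(C)[C@H]2CCCc4cccnc42)NC3)C1` holds the second highest of three numbers in an ADME assay on microsomes from liver (Mus musculus) for metabolic stability, using NADPH, with a stated time of 10 min; on this read-out higher numbers stand for a more stable compound and lower numbers for a less stable compound: it gives 28.2%. Its nearest neighbour is compound 1 `CN1CC[C@H]2CN(c3cccc4c3C[C@H](CN(C)[C@H]3CCCc5cccnc53)NC4)C[C@H]21`, which gives 24%, and a number 4.2 percentage points higher from compound 1 to compound 3 (within the scatter). Far above both stands compound 2 `CN(C[C@H]1Cc2c(cccc2N[C@H]2CC[C@H](N)CC2)CN1)[C@H]1CCCc2cccnc21`, which gives 100%; a number 71.8 percentage points lower from compound 2 to compound 3 (beyond the scatter) and a number 76 percentage points higher from compound 1 to compound 2 (beyond the scatter). Compound 4 `CN(C)[C@H]1CCN(c2cccc3c2C[C@H](CN(C)[C@H]2CCCc4cccnc42)NC3)C1` keeps every atom and bond of compound 3: the two compounds have the same atoms and bonds and differ only in configuration as drawn: 1 of 3 stereo elements differ; a stereocentre at a saturated ring carbon is drawn R in compound 3 and S in compound 4. Among the compounds with values here, none of the measured steps alters configuration alone; both steps reaching compound 3 exchange whole groups on an aromatic carbon. The measured steps therefore offer no direct guide to this change, and the expectation is a step of a number 0.2 percentage points lower from compound 3 to compound 4 (within the scatter), none beyond the scatter. Compound 4 is estimated at 28%, within 12% to 50%.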

Compound 4, percent of the compound remaining: 18.5%
The estimate for compound 4 lay 9.5 percentage points above the measured number, and the stated range covers the measured number.
By their numbers in this assay, from the lowest: compounds 4, 1 and 3 (each within the scatter of the next); then compound 2.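

In this assay, inverting this saturated ring carbon from R to S gives a number 9.7 percentage points lower from compound 3 to compound 4 (within the scatter), so no effect of this stereocentre can be read here. The S form also stays far from (4-aminocyclohexyl)amino, with a number 81.5 percentage points lower from compound 2 to compound 4 (beyond the scatter), and level with the group of compound 1, with a number 5.5 percentage points lower from compound 1 to compound 4 (within the scatter). The large gap to compound 2 thus holds for both drawings, and this pair tests a single change: the fact that compounds 3 and 4 differ only in the configuration as drawn. Still open, going by these compounds, is whether a primary amine in place of dimethylamino on the pyrrolidine ring would close that gap.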